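The source may hold more compounds than are shown below. What is called first, only, known or untested is meant among the compounds shown, and "the series" means these compounds.

Going by the values given here, compound 2 `Cn1c(=O)c(=O)n(C2CCCC2)c2nc(N/N=C/c3ccco3)ncc21` is one of two compounds measured in a functional assay on PC-3 cells (Homo sapiens) for antiproliferative activity, read by MTT assay; on this read-out higher numbers stand for weaker inhibition and lower numbers for stronger inhibition; in this assay compound 2 gives 72200 nM, the highest number of the two and so the weaker inhibitor. Compound 1 `Cn1c(=O)c(=O)n(C2CCCC2)c2nc(N/N=C/c3cc(C(F)(F)F)c(O)c(C(F)(F)F)c3)ncc21` carries a substituted six-membered aromatic ring of carbon only on a carbon with a double bond to nitrogen and gives 17700 nM, a number well below that of compound 2. Compound 3 `Cn1c(=O)c(=O)n(C2CCCC2)c2nc(N/N=C/c3cc([N+](=O)[O-])ccc3Cl)ncc21` has not yet been measured. It differs from compound 2 in a single place: 2-chloro-5-nitrophenyl in place of furan-2-yl on a carbon with a double bond to nitrogen. Among the compounds with values here, no measured pair shows this exact exchange, so the only guide is compound 1, whose lower number 17700 nM goes with a six-membered aromatic ring of carbon only in the same place. A modest drop in the number is therefore expected, a 2.4-fold lower number from compound 2 to compound 3 (0.38 log units; beyond the scatter), though a result within the scatter would not surprise. Compound 3 is estimated at 30000 nM, with a range from 9000 nM to 90000 nM.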

Compound 3, half-maximal inhibitory concentration: 9260 nM
Estimate against measurement, compound 3: 3.2-fold (0.51 log units) above, within the range that was stated.
By their numbers in this assay, from the lowest: compounds 3 and 1 (each within the scatter of the next); then compound 2.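

The exchange of furan-2-yl for 2-chloro-5-nitrophenyl on a carbon with a double bond to nitrogen now gives a direct one-place comparison in this assay: a 7.8-fold lower number from compound 2 to compound 3 (0.89 log units; beyond the scatter). Compound 1 at 17700 nM and compound 3 at 9260 nM lie within the scatter of each other, so two differently substituted six-membered aromatic rings of carbon only give matching results at this position. No measurement available here accounts for the step.

The chlorine, the nitro group and the six-membered ring all enter together, so the compounds shown cannot separate their contributions. From the compounds shown here alone, whether an unsubstituted phenyl ring, or a ring carrying an amine in place of the nitro group, would keep the lower number remains open.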